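This account rests on a few compounds, and the source may have more. Where it says the series, first, only, none or still open, it means among the compounds named here.

Measured in an ADME assay on Vero cells (Chlorocebus sabaeus) for cytotoxicity; on this read-out lower numbers stand for higher toxicity in this test and higher numbers for lower toxicity in this test:
Compound 1 `C[C@]1(CO)O[C@@H](n2cc(-c3ccco3)c3c(N)ncnc32)[C@H](O)[C@@H]1O`: > 50000 nM, a limit
Compound 2 `C[C@]1(CO)O[C@@H](n2cc(-c3cccs3)c3c(N)ncnc32)[C@H](O)[C@@H]1O`: > 50000 nM, a limit

In this assay compound 1 stands only at its limit of > 50000 nM, with no number behind it. Both measured compounds sit at the same limit: the limit of > 50000 nM in this assay, at which 2 of the 2 values shown sit. The next compound is compound 3 `C#Cc1cn([C@@H]2O[C@](C)(CO)[C@@H](O)[C@H]2O)c2ncnc(N)c12`, and the change from compound 1 is ethynyl in place of furan-2-yl on an aromatic carbon. For the measured compounds named here, only one measured step bears on this position, a step that the two limits leave unreadable from compound 1 to compound 2, with thiophen-2-yl in place of furan-2-yl. Going by the values given here, it offers no size to carry over, and no compound with ethynyl has a measured value. Among the compounds with values here, no step of definite size is therefore expected in this assay, though any readable move would have to be toward lower numbers. The expected change is a number no higher from compound 1 to compound 3 (the limit leaves the size open). Compound 3 is estimated at 50000 nM, with an expected range of 10000 nM to 100000 nM.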

Compound 3, half-maximal cytotoxic concentration: 13400 nM
Estimate against measurement, compound 3: 3.7-fold (0.57 log units) above, and the stated range covers the measured number.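

In this assay, this position now shows that it can move the read-out: ethynyl in place of furan-2-yl gives an at least 3.7-fold lower number from compound 1 to compound 3 (0.57 log units; beyond the scatter), and ethynyl in place of thiophen-2-yl gives an at least 3.7-fold lower number from compound 2 to compound 3 (0.57 log units; beyond the scatter). Both steps are lower bounds, and the step between compound 1 and compound 2 cannot be read. Compound 3 is the only compound of the three with a number rather than a limit, and the two aromatic groups stay together at that limit: the limit of > 50000 nM in this assay, at which 2 of the 3 values shown sit.

On these data alone, whether the lower number follows from the triple bond itself or from the loss of the five-membered aromatic ring remains open. An ethyl group or a nitrile at this carbon could separate the two, and a longer alkyne would show whether the change depends on the size of the group.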